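Swapping a side chain on a shared coumarin-like core

This account rests on a few compounds, and the source may have more. Where it says the series, first, only, none or still open, it means among the compounds named here.

Compounds measured so far:
compound 1 `COc1cc(=O)oc2cc(OCc3cccc(F)c3)ccc12` — 36.3 nM
compound 2 `COc1cc(=O)oc2cc(OCc3cccc(Br)c3)ccc12` — 5.75 nM
compound 3 `CNC(=O)COc1cc(=O)oc2cc(OCc3cccc(Cl)c3)ccc12` — 33.9 nM

In an assay on isolated protein (strain Sprague-Dawley) for inhibition of Amine oxidase [flavin-containing] B (Rattus norvegicus), read by spectrophotometry, with a stated time of 5 min (a higher number here means a weaker inhibitor, a lower number a stronger inhibitor), compound 3 stands second highest of the three numbers, close to compound 1 and well apart from compound 2. Compound 4 `O=c1cc(CCl)c2ccc(OCc3cccc(Cl)c3)cc2o1` differs from compound 3 by chloromethyl in place of (methylcarbamoyl)methoxy on an aromatic carbon. For the measured compounds named here, the one measured step, a 6.3-fold lower number from compound 1 to compound 2 (0.80 log units; beyond the scatter), concerns a halogen swap on the benzyl ring, not the group exchanged here, so no measured step bears directly on this change. The expectation therefore rests on the spread of the three numbers alone: compound 4 is expected to land near the middle, with a 1.7-fold lower number from compound 3 to compound 4 (0.23 log units; within the scatter). The estimate for compound 4 is 20 nM, within the range 4 nM to 100 nM.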

Compound 4, half-maximal inhibitory concentration: 43.7 nM
Estimate against measurement, compound 4: 2.2-fold (0.34 log units) below; the range from low to high includes it.
By their numbers in this assay, from the lowest: compound 2; then compounds 3, 1 and 4 (each within the scatter of the next).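

In this assay, chloromethyl in place of (methylcarbamoyl)methoxy on this aromatic carbon gives a 1.3-fold higher number from compound 3 to compound 4 (0.11 log units; within the scatter), so the two compounds cannot be told apart. At this position, then, the much smaller chloromethyl, which carries no hydrogen-bond donor or acceptor, reads the same as the larger amide-bearing chain, at least with this benzyl ring. Nothing shown explains why these two groups read alike.

Going by these compounds, whether an amine, a carboxylic acid or a longer chain would read the same here remains open. So does whether this match holds with bromo in place of chloro on the benzyl ring.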